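The source may report more compounds than this note shows. Statements on the series, on what has been measured and on what is new or still open speak of the compounds shown alone.

Working notes on the sulfonyl series in an assay on isolated protein for displacement of a labelled ligand from metabotropic glutamate receptor 5 (Homo sapiens), with a stated time of 60 min, tested at 1 uM; a lower number here means less inhibition, a higher number more inhibition at the concentration tested (going by the name of the read-out).

Going by the values given here, three analogues sharing one core have numbers so far. Compound 1 `Cc1ccc2ncc(S(=O)(=O)c3cc(Cl)cc(Cl)c3)c(N3CCC(C)CC3)c2c1` gives 75%. Compound 2 `Cc1cc(C)cc(S(=O)(=O)c2cnc3ccc(C)cc3c2N2CCC(C)CC2)c1` gives 80%, and compound 3 `Cc1ccc2ncc(S(=O)(=O)c3cc(F)cc(F)c3)c(N3CCC(C)CC3)c2c1` gives 72%. All three measured steps change only the aryl group on the sulfonyl sulfur: a number 5 percentage points higher from compound 1 to compound 2 (within the scatter), a number 3 percentage points lower from compound 1 to compound 3 (within the scatter) and a number 8 percentage points lower from compound 2 to compound 3 (within the scatter). None of them goes beyond the scatter, so the three aryl groups are not separated by these data. Compound 2 holds the highest of the three numbers, but its steps to compound 1 and compound 3 are both within the scatter, so its number cannot be set apart from theirs.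

Compound 4 `COc1ccc2ncc(S(=O)(=O)c3cc(C)cc(C)c3)c(N3CCC(C)CC3)c2c1` keeps the 3,5-dimethylphenyl of compound 2 and alters the core instead: methoxy in place of methyl on an aromatic carbon. Among the compounds with values here, no measured step touches this position; every comparison available concerns the sulfonyl aryl group, so the effect of methoxy on an aromatic carbon of the fused two-ring system is unprobed. With nothing pointing either way, no step beyond the scatter is expected, and the estimated step is a number 3 percentage points lower from compound 2 to compound 4 (within the scatter). Compound 4 is therefore estimated at 77%, with a range from 58% to 92%.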

Compound 4, a percentage reported as inhibition, at one concentration (the size of the read-out at that concentration, not a potency): 79%
Estimate against measurement, compound 4: 2 percentage points below; the range from low to high includes it.
By their numbers in this assay, from the lowest: compounds 3, 1, 4 and 2 (each within the scatter of the next).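

In this assay this aromatic carbon, meta to a fused ring and para to a fused ring, now has its first reading: methoxy in place of methyl comes with a number 1 percentage points lower from compound 2 to compound 4 (within the scatter) and is not separated by these data from leaving methyl in place. The change adds an oxygen and the hydrogen-bond acceptor counted for methoxy, yet the number does not shift beyond the scatter, so the series now has a second varied place alongside the aryl group on the sulfonyl sulfur, and neither has yet produced a step that can be told from the scatter. This reading holds for the 3,5-dimethylphenyl compounds only, and nothing available bears on why the step is so small.

Open, going by these compounds, is whether a group of another kind on this aromatic carbon, such as an amine, a carboxylic acid or a longer alkoxy chain, would move the number beyond the scatter. Also open, on these data alone, is whether methoxy would give a similar step with 3,5-dichlorophenyl or 3,5-difluorophenyl on the sulfonyl sulfur.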